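Removing a fluoro substituent from a benzylamide series

The compounds below may be only part of what the source reports. "The series", "measured", "known", "first", "only" and "open" are said of these compounds alone.

The study concerns three measured compounds and one that awaits its number. Compound 1 `CS(=O)(=O)c1ccc(C(=O)N2CCC(C(=O)N(Cc3ccccc3)Cc3ccccc3)CC2)cc1[N+](=O)[O-]` was tested in an assay on isolated protein for inhibition of vitamin D3 receptor (Homo sapiens), read by fluorescence polarization (a higher number here means a weaker inhibitor, a lower number a stronger inhibitor), and gave only a limit of the assay, > 60000 nM. Compound 2 `CC1CCN(C(=O)CCCNC(=O)c2ccc(S(C)(=O)=O)c([N+](=O)[O-])c2)CC1` likewise returned only a limit, > 60000 nM. Compound 3 `CN(Cc1ccccc1F)C(=O)C1CCN(C(=O)c2ccc(S(C)(=O)=O)c([N+](=O)[O-])c2)CC1` also sits at a limit, > 60000 nM, so none of the three carries a numerical value, and compound 3 cannot be ranked against the other two: the data place all of them at the limit of > 60000 nM in this assay, at which 3 of the 3 values shown sit.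

Compound 4 `CN(Cc1ccccc1)C(=O)C1CCN(C(=O)c2ccc(S(C)(=O)=O)c([N+](=O)[O-])c2)CC1` is the next member. It differs from compound 3 by hydrogen in place of fluoro on an aromatic carbon. Among the measured compounds shown here, no measured pair in this set isolates such a change, so there is no step to lean on; what can be said is that compound 3 shows no measurable inhibition at all, and a change that removes a single fluorine gives no grounds to expect that to alter. The step from compound 3 to compound 4 is therefore expected to be a step that the limit leaves unreadable from compound 3 to compound 4, that is none beyond the scatter, with the assay most likely again reporting only a limit. The estimated value for compound 4 in this assay is 80000 nM, with a range from 30000 nM to 200000 nM.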

Compound 4, half-maximal inhibitory concentration: > 60000 nM
Compound 4 gave a limit, no number; the forecaster's own chance of this, stated with the estimate: 85%; the middle value lies beyond the limit too.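

In this assay, neither the step from compound 3 to compound 4 nor the step from compound 1 to compound 4 can be read, because these compounds give a limit and no number: the limit of > 60000 nM in this assay, at which 4 of the 4 values shown sit.

The compounds shown leave open whether any of them inhibits the receptor measurably, and whether fluoro or hydrogen on the aromatic carbon makes any difference.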